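The compounds below may be only part of what the source reports. "The series", "measured", "known", "first", "only" and "open" are said of these compounds alone.

Compound 1 `O=C(/C=C/c1ccc(O)cc1)O[C@@H]1C[C@](OC(=O)/C=C/c2ccc(O)c(O)c2)(C(=O)O)C[C@@H](O)[C@H]1O`: 23500 nM
Compound 2 `O=C(/C=C\c1ccc(O)cc1)O[C@@H]1C[C@](OC(=O)/C=C/c2ccc(O)cc2)(C(=O)O)C[C@@H](O)[C@H]1O`: 59800 nM

In a functional assay on BV-2 cells (Mus musculus) for inhibition, read by Griess assay, with a stated time of 10 min (on this read-out lower numbers stand for stronger inhibition and higher numbers for weaker inhibition), compound 2 gives 59800 nM, the highest of the two numbers; compound 1 gives 23500 nM, and that gap lies beyond the scatter. Compound 3 `O=C(/C=C\c1ccc(O)cc1)O[C@@H]1C[C@](OC(=O)/C=C\c2ccc(O)cc2)(C(=O)O)C[C@@H](O)[C@H]1O` differs from compound 2 as follows: the two compounds have the same atoms and bonds and differ only in configuration as drawn: 1 of 6 stereo elements differ; a double bond is drawn E in compound 2 and Z in compound 3. Among the measured compounds shown here, no measured pair shows such a change, so its effect is unknown. The step from compound 2 to compound 3 is expected to be small, a 1.3-fold higher number from compound 2 to compound 3 (0.13 log units; within the scatter), probably not beyond the scatter. Compound 3 is estimated at 80000 nM, within 30000 nM to 200000 nM.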

Compound 3, half-maximal inhibitory concentration: 52800 nM
Beside the measured number, compound 3's estimate is 1.5-fold (0.18 log units) above it; measured number inside the range.
By their numbers in this assay, from the lowest: compound 1; then compounds 3 and 2 (each within the scatter of the next).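

Among the compounds shown here, compounds 2 and 3 form the first pair in which a single change can be read in this assay: redrawing one double bond from E to Z gives a 1.1-fold lower number from compound 2 to compound 3 (0.05 log units; within the scatter). With the other double bond drawn Z in both compounds, the geometry at this position therefore moves the number no further than the scatter, and the comparison rests on one difference alone: the fact that compounds 2 and 3 differ only in the configuration as drawn.

Going by these compounds, whether this holds when the other double bond is drawn E remains open. So does how the number would respond if a methyl ester or an amide stood in place of the carboxylic acid.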